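The source may report more compounds than this note shows. Statements on the series, on what has been measured and on what is new or still open speak of the compounds shown alone.

In a functional assay on HFF cells (Homo sapiens) for cytotoxicity (a higher number here means a weaker inhibitor, a lower number a stronger inhibitor), compound 1 `CSc1nc(Cl)c2ccn(COCCO)c2n1` gives 30000 nM. For compound 2 `COc1nc(N)c2ccn(COCCO)c2n1` the assay reports only a limit, > 100000 nM. For compound 3 `CC(=O)Nc1nc(Cl)c2ccn(COCCO)c2n1` the assay likewise reports a limit, > 100000 nM. Going by the values given here, the single measured step, an at least 3.3-fold higher number from compound 1 to compound 3 (0.52 log units; beyond the scatter), therefore ends at the limit of > 100000 nM in this assay, at which 2 of the 3 values shown sit. Compound 2 thus stands at that same limit, without a number of its own. Compound 4 `Nc1nc(N)c2ccn(COCCO)c2n1` differs from compound 2 by amino in place of methoxy on an aromatic carbon. Among the compounds with values here, no measured step covers this change, and the one known step ran toward the limit rather than away from it. In this assay the step of a number no higher from compound 2 to compound 4 (the limit leaves the size open) is expected to stay within the scatter. Compound 4 is accordingly estimated at 100000 nM, with a range from 40000 nM to 300000 nM, and most likely again only a limit.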

Compound 4, half-maximal inhibitory concentration: > 100000 nM
Compound 4: no number, only a limit; the forecaster's own chance of this, stated with the estimate: 70%; the middle value sits exactly at the limit.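

Compound 2 and compound 4 both give only a limit in this assay, so no step can be read between them: the limit of > 100000 nM in this assay, at which 3 of the 4 values shown sit.

On these data alone, whether amino in place of methoxy changes the read-out at all, and in which direction, stays open.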